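Methyl to Cyclopropyl on the Pyrazole: an Expected Value

The compounds below may be only part of what the source reports. "The series", "measured", "known", "first", "only" and "open" are said of these compounds alone.

Of the compounds shown here, three built on one shared core have been measured in an assay for inhibition of high affinity nerve growth factor receptor (Homo sapiens), read by HTRF, with a stated time of 30 min, in the presence of a further agent that is not named here; on this read-out higher numbers stand for weaker inhibition and lower numbers for stronger inhibition. Compound 1 `Fc1ccc(CNc2nc(Nc3cc(C4CC4)[nH]n3)c3ccccc3n2)c(F)c1` gives 4.7 nM. Compound 2 `Fc1ccc(CNc2nc(Nc3cc(C4CC4)[nH]n3)c3ccc(Cl)cc3n2)c(F)c1` gives 290 nM. Compound 3 `Cc1cc(Nc2nc(NCc3ccc(F)cc3F)nc3cc(Br)ccc23)n[nH]1` gives 53 nM, which places it second highest of the three numbers: its nearest neighbour is compound 2, and its furthest is compound 1, both separated from it by more than the usual scatter.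

For the measured compounds named here, the only single-point step measured so far is a 62-fold higher number from compound 1 to compound 2 (1.79 log units; beyond the scatter), a large loss of inhibition from adding a halogen to the benzo ring of the core. Compound 4 `Fc1ccc(CNc2nc(Nc3cc(C4CC4)[nH]n3)c3ccc(Br)cc3n2)c(F)c1` carries a bromo group at that same position, as compound 3 does, so this step does not describe the change now at hand; it only shows that substituents on this core can move the number a long way.

The change from compound 3 to compound 4 is cyclopropyl in place of methyl on an aromatic carbon. Going by the values given here, no measured pair isolates this exchange, so the direction is open. Compound 2, which already carries the cyclopropyl pyrazole, sits above compound 3, and compound 4 is expected to land near it, giving a 3.4-fold higher number from compound 3 to compound 4 (0.53 log units; beyond the scatter). The estimated value for compound 4 is 180 nM, within 50 nM to 600 nM.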

Compound 4, half-maximal inhibitory concentration: 150 nM
Beside the measured number, compound 4's estimate is 1.2-fold (0.08 log units) above it; the range from low to high includes it.
By their numbers in this assay, from the lowest: compound 1; then compound 3; then compounds 4 and 2 (each within the scatter of the next).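

For the compounds shown here, with the bromo group held constant, compound 3 and compound 4 isolate the exchange of 5-methyl-1H-pyrazol-3-yl for 5-cyclopropyl-1H-pyrazol-3-yl for the first time, and in this assay it gives a 2.8-fold higher number from compound 3 to compound 4 (0.45 log units; beyond the scatter), so the larger group on this aromatic carbon of the pyrazole comes with a modest loss of inhibition in this pair. The halogen can now be compared as well: a 1.9-fold lower number from compound 2 to compound 4 (0.29 log units; within the scatter), which lies within the scatter, so this assay does not tell bromo and chloro apart on this core. The large cost seen earlier with chloro also appears with bromo, at a 32-fold higher number from compound 1 to compound 4 (1.50 log units; beyond the scatter), and this halogen step is much bigger than the modest pyrazole step.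

Nothing available here accounts for either step. The compounds shown leave open whether the exchange of methyl for cyclopropyl reads the same on the core of compound 1, which has no halogen, and how a longer chain such as propyl, or an amine, would fare on the same pyrazole carbon.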